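Bromo for chloro: one halogen swap, two cores

A few compounds are considered here, and "the series" means these few. Any claim that something is new, unique, unknown or untested is made for them only; others in the source may bear on it.

The measured compounds are:
Compound 1, `N=C(N)Nc1cccc(C(=O)NNC(=O)CC(CC(=O)O)c2ccc(Cl)cc2)c1`, which in a physicochemical assay for lipophilicity (a lower number here means a more polar compound, a higher number a more lipophilic compound), gives 1.68.
Compound 2, `N=C(N)Nc1cccc(C(=O)NNC(=O)CC(CC(=O)O)c2ccc(Br)cc2)c1`, which in this assay gives 1.95.
Compound 3, `N=C(N)Nc1cccc(C(=O)NNC(=O)NC(CC(=O)O)c2ccc(Cl)cc2)c1`, which in this assay gives 1.26.

Compound 1 and compound 2 share a core and differ only in the change (bromo in place of chloro on an aromatic carbon). This change moved the number a number 0.27 log units higher from compound 1 to compound 2 (within the scatter), so the two values cannot be told apart with confidence. Compound 3 is built on a different core; the difference between the two cores is not broken down here. Its number is the lowest of the three, with compound 1 nearest and compound 2 furthest, and both of those gaps are beyond the scatter.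

Compound 4, `N=C(N)Nc1cccc(C(=O)NNC(=O)NC(CC(=O)O)c2ccc(Br)cc2)c1`, has not yet been measured. It differs from compound 3 by bromo in place of chloro on an aromatic carbon, the same change, in the same place, that separates compound 1 from compound 2. Going by the values given here, the only guide to its size is that earlier pair, so for compound 4 a step of a number 0.27 log units higher from compound 3 to compound 4 (within the scatter) is expected in this assay. If that holds, compound 4 is expected to give about 1.53, with a likely range from 1.25 to 1.85. Among the compounds with values here, that expectation rests on compound 1 and compound 2 alone, because a number 0.27 log units higher from compound 1 to compound 2 (within the scatter) is the only measured instance of this swap, and it assumes the swap behaves alike on the second core.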

Compound 4, partition coefficient: 1.53
Estimate against measurement, compound 4: no gap at the digits printed; low and high end bracket the measured number.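

In this assay, bromo in place of chloro on the aromatic ring gives a number 0.27 log units higher from compound 3 to compound 4 (within the scatter), and on the other core the same swap gives a number 0.27 log units higher from compound 1 to compound 2 (within the scatter), so the two steps read alike at the digits printed and the change carried across these two cores without any visible surprise. This is a modest result: each step lies within the scatter, so neither pair on its own separates the bromo compound from its chloro partner with confidence, and two matching steps on two cores make no rule for a third core or for a different place on the ring. Nothing shown here explains why the steps match, and the agreement could be partly chance given how small they are.

The compounds shown leave open how other groups at the same place on the ring would behave, such as fluoro, methyl, trifluoromethyl or nitrile, and whether any of these would give a step clear of the scatter. They also leave open whether the match would survive on a core with a longer chain in place of the one carrying the carboxylic acid.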